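A few compounds are considered here, and "the series" means these few. Any claim that something is new, unique, unknown or untested is made for them only; others in the source may bear on it.

Compound 1, with the structure `NC(=O)c1ccc(-c2cnc(C(O)CCc3ccc(-c4ccccc4)cc3)o2)nc1`, gives in an assay for inhibition of Fatty-acid amide hydrolase 1 (Rattus norvegicus) (on this read-out higher numbers stand for weaker inhibition and lower numbers for stronger inhibition), only a limit, > 1000 nM, and not a number. It therefore sits at the weak end of the values seen, on (the limit of > 1000 nM in this assay, at which 1 of the 2 values shown sits). Compound 2, of structure `COC(=O)c1ccc(-c2cnc(C(=O)CCc3ccc(-c4ccccc4)cc3)o2)cn1`, is a different matter: in this assay compound 2 gives 0.6 nM, but it differs from compound 1 in more than one place, so its value shows only how far apart the two compounds lie. Compound 3, with the structure `COC(=O)c1cccc(-c2cnc(C(O)CCc3ccc(-c4ccccc4)cc3)o2)n1`, has not been measured. It differs from compound 1 in one place, (6-(methoxycarbonyl)pyridin-2-yl in place of 5-carbamoylpyridin-2-yl on an aromatic carbon). With compound 1 known only as a limit, the step from compound 1 to compound 3 is expected to be small, with an expected change of a step that the limit leaves unreadable from compound 1 to compound 3, or none beyond the scatter. Compound 3 is therefore estimated at 1500 nM, within a range from 300 nM to 8000 nM.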

Compound 3, inhibition constant: 9000 nM
Estimate against measurement, compound 3: 6.0-fold (0.78 log units) below, outside the stated range (above it).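

No step can be read between compound 1 and compound 3, because compound 1 stands in this assay only as a limit: the limit of > 1000 nM in this assay, at which 1 of the 3 values shown sits. The compounds shown leave open how 5-carbamoylpyridin-2-yl and 6-(methoxycarbonyl)pyridin-2-yl compare on the shared core, and which single change separates compound 2 from the others.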